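Thiophen-2-yl in place of methyl: a small step expected

The source may report more compounds than this note shows. Statements on the series, on what has been measured and on what is new or still open speak of the compounds shown alone.

Three related compounds have been measured so far. In a functional assay on SH-SY5Y cells (Homo sapiens) for cytotoxicity, read by MTT assay, with a stated time of 72 h (on this read-out higher numbers stand for weaker inhibition and lower numbers for stronger inhibition), compound 1 `S=C=NCCCCSCc1ccccc1` gives 20700 nM, compound 2 `CC[S+]([O-])CCCCN=C=S` gives 9810 nM and compound 3 `[O-][S+](CCCCN=C=S)c1ccccc1` gives 8750 nM. Compound 2 and compound 3 therefore lie within the usual scatter of repeated measurements of each other, while compound 1 shows a higher number, beyond that scatter from compound 2.

The next compound to be tested is compound 4 `[O-][S+](CCCCN=C=S)Cc1cccs1`. It differs from compound 2 by having thiophen-2-yl in place of methyl on a saturated chain carbon bound to a sulfur. Among the measured compounds shown here, no measured pair shows this exact swap, so any forecast is indirect. Compound 3 also carries a ring, and its 8750 nM sits within the scatter of compound 2. That points to little change. Compound 1 is the caution, since it too carries a ring, has no oxygen on its sulfur, and gives 20700 nM. The expected result in this assay is no change beyond the scatter, with an estimated step of a 1.2-fold lower number from compound 2 to compound 4 (0.06 log units; within the scatter). For compound 4 the estimated value is 8500 nM, with an expected range from 4000 nM to 18000 nM.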

Compound 4, half-maximal inhibitory concentration: 5310 nM
Compound 4: the middle estimate sits 1.6-fold (0.20 log units) above what was measured; the measured number falls inside the stated range.
By their numbers in this assay, from the lowest: compounds 4, 3 and 2 (each within the scatter of the next); then compound 1.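

In this assay, among the compounds shown here, placing thiophen-2-yl in place of methyl on a saturated chain carbon bound to a sulfur gives a 1.8-fold lower number from compound 2 to compound 4 (0.27 log units; within the scatter) and provides the first direct reading of a swap at this position. The change is sizeable on paper, since a single carbon leaves and a group of 5 heavy atoms with one five-membered aromatic ring enters, yet the two compounds cannot be told apart in this cytotoxicity read-out, so a ring of this kind is tolerated here without a shift that stands clear of ordinary repeat-to-repeat variation. No measurement at hand explains this outcome, which therefore remains a plain observation from a single pair.

On these data alone, what a phenyl ring, a furan-2-yl ring or a pyridine ring would give on that same chain carbon remains open, as does the effect of an amine or a carboxylic acid placed there. Also open, as far as these compounds go, is whether thiophen-2-yl would give a similar step on a longer chain or in a compound whose sulfur carries no oxygen.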